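Chain length and cytotoxicity in a tetrabrominated series

The compounds below may be only part of what the source reports. "The series", "measured", "known", "first", "only" and "open" are said of these compounds alone.

Compound 2 `N#CCCn1cnc2c(Br)c(Br)c(Br)c(Br)c21` is the lower of two measured numbers in a functional assay on CCRF-CEM cells (Homo sapiens) for cytotoxicity, read by MTT assay, with a stated time of 24 h, tested at 50 uM; a lower number here means a stronger effect, a higher number a weaker effect of the compound at the concentration tested. In this assay compound 2 gives 2%, while compound 1 `Cc1nc2c(Br)c(Br)c(Br)c(Br)c2n1CCCCC#N` gives 55%, a gap beyond the usual scatter. Compound 3 `N#CCCCCn1cnc2c(Br)c(Br)c(Br)c(Br)c21` has not been measured; it differs from compound 2 by 2-cyanoethyl in place of cyano on a saturated chain carbon, two bonds along the chain from an aromatic nitrogen. Compound 1 carries a chain of the same length and sits much higher, so a rise is expected, though compound 1 also carries a methyl group that compound 3 lacks. The estimated step from compound 2 to compound 3 is a number 28 percentage points higher from compound 2 to compound 3 (beyond the scatter). Compound 3 is expected to give 30%, in the range 5% to 60%.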

Compound 3, a percentage reported as activity, at one concentration (the size of the read-out at that concentration, not a potency): 1%
Compound 3: middle estimate off by 29 percentage points, on the high side; the measured number lies below the stated range.
By their numbers in this assay, from the lowest: compounds 3 and 2 (each within the scatter of the next); then compound 1.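

In this assay, 2-cyanoethyl in place of cyano on a saturated chain carbon, two bonds along the chain from an aromatic nitrogen, gives a number 1 percentage points lower from compound 2 to compound 3 (within the scatter) and so leaves the read-out unchanged. Hydrogen in place of methyl on an aromatic carbon gives a number 54 percentage points lower from compound 1 to compound 3 (beyond the scatter), which places the large gap with the methyl group rather than the chain. Nothing available explains the size of either step. Still open, as far as these compounds go, is whether a longer chain, or an amine or carboxylic acid in place of the nitrile, would keep the read-out this low.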